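One Stereocentre Drawn In: From Compound 1 to Compound 4

A few compounds are considered here, and "the series" means these few. Any claim that something is new, unique, unknown or untested is made for them only; others in the source may bear on it.

Compound 1 `OCC(O)COc1nc(N2CCCCC2)c2nc(OCC(O)CO)nc(N3CCCCC3)c2n1`: 83%
Compound 2 `c1nc(N2CCCCC2)c2ncnc(N3CCCCC3)c2n1`: "not active" (no number reported)
Compound 3 `COCC(C)Oc1nc(N2CCCCC2)c2nc(OC(C)COC)nc(N3CCCCC3)c2n1`: 96%

Of the compounds shown here, three share one core and have been tested in a functional assay on L1210 cells (Mus musculus) for inhibition, read by thymidine incorporation, tested at 100 uM; a lower number here means a weaker effect, a higher number a stronger effect of the compound at the concentration tested. Compound 1 gives 83% in this assay, the lower of the two numbers that were obtained. Compound 3 reads higher, and the gap between compound 1 and compound 3 lies beyond the usual scatter of repeated measurements. Compound 2, which carries no side chains on the core, is reported as "not active" (no number reported), without a number.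

The next compound, compound 4 `OCC(O)COc1nc(N2CCCCC2)c2nc(OC[C@@H](O)CO)nc(N3CCCCC3)c2n1`, keeps every atom and bond of compound 1. The only difference is this: the two compounds have the same atoms and bonds; at least one stereo element is drawn with a configuration in one of them and without one in the other: 1 of 2 stereo elements differ; a stereocentre at a saturated chain carbon is drawn without a configuration in compound 1 and S in compound 4. Because compound 1 already reaches 83% and compound 4 is the same substance drawn with one configuration fixed, the expected step of no change at the digits printed from compound 1 to compound 4 (within the scatter) is none beyond the scatter. For compound 4 a value of about 83% is estimated, within a range from 70% to 94%.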

Compound 4, a percentage reported as inhibition, at one concentration (the size of the read-out at that concentration, not a potency): 91%
Compound 4: middle estimate off by 8 percentage points, on the low side; the range from low to high includes it.
By their numbers in this assay, from the lowest: compounds 1, 4 and 3 (each within the scatter of the next, the first and the last beyond it).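

Going by these compounds alone, until this pair, no compound in the set was drawn with a configuration, so nothing could be read about a stereocentre on its own. In this assay the step is a number 8 percentage points higher from compound 1 to compound 4 (within the scatter) and so, at this saturated chain carbon, the compound with the S configuration drawn cannot be told apart from the one drawn without a configuration. Only one thing separates the two compounds: the fact that one of compounds 1 and 4 is drawn with a defined configuration and the other without, at the place where they differ.

The compounds shown leave open how the R configuration at this carbon would read, and whether the second stereocentre, still drawn without a configuration in compound 4, matters at all. They also leave open whether a side chain ending in an amine or a carboxylic acid would read differently from the chains carried by compound 1 and compound 4.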